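From furan-3-yl to 2-chlorophenyl on a shared core

The compounds below may be only part of what the source reports. "The series", "measured", "known", "first", "only" and "open" are said of these compounds alone.

Measured so far in a functional assay on LN-229 cells (Homo sapiens) for antiproliferative activity, with a stated time of 72 h; on this read-out higher numbers stand for weaker inhibition and lower numbers for stronger inhibition
- compound 1 `Nc1ncnn2c([C@@H]3O[C@H](CO)[C@@H](O)[C@H]3O)cc(C#CC3CC3)c12` gives 30 nM
- compound 2 `Nc1ncnn2c([C@@H]3O[C@H](CO)[C@@H](O)[C@H]3O)cc(C#Cc3ccccc3)c12` gives 88000 nM
- compound 3 `Nc1ncnn2c([C@@H]3O[C@H](CO)[C@@H](O)[C@H]3O)cc(-c3ccoc3)c12` gives 1000 nM

Among these three numbers, compound 3 (1000 nM) stands in the middle, with compound 1 lower and compound 2 higher. Compound 4 `Nc1ncnn2c([C@@H]3O[C@H](CO)[C@@H](O)[C@H]3O)cc(-c3ccccc3Cl)c12` keeps the shared core but carries 2-chlorophenyl in place of furan-3-yl on an aromatic carbon in the same spot.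

Changes at this spot have mattered a great deal. The group there gave a 33-fold higher number from compound 1 to compound 3 (1.52 log units; beyond the scatter) and an 88-fold lower number from compound 2 to compound 3 (1.94 log units; beyond the scatter), both large. The closest hint about a six-membered aromatic ring is a 2900-fold higher number from compound 1 to compound 2 (3.47 log units; beyond the scatter), where phenyl replaced cyclopropyl on the triple-bonded carbon. Within the data shown here, that is one case, though, and no measured compound carries a chlorine or a phenyl ring attached directly to the core.

A rise in the number is therefore expected, with low confidence. In this assay the expected change is a 5.0-fold higher number from compound 3 to compound 4 (0.70 log units; beyond the scatter) as an estimate. Compound 4 is estimated at 5000 nM, with an expected range from 600 nM to 40000 nM as the likely span.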

Compound 4, half-maximal inhibitory concentration: > 100000 nM
Compound 4 was reported as a limit; the forecaster's own chance of this, stated with the estimate: 10%; middle value at least 20-fold (1.30 log units) from the limit.
By their numbers in this assay, from the lowest: compound 1; then compound 3; then compound 2. At a limit, above all of these: compound 4.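

In this assay compound 4 is reported only as a limit: the limit of > 100000 nM in this assay, at which 1 of the 4 values shown sits. At this spot, 2-chlorophenyl in place of furan-3-yl gives an at least 100-fold higher number from compound 3 to compound 4 (2.00 log units; beyond the scatter) and in place of 2-cyclopropylethynyl gives an at least 3300-fold higher number from compound 1 to compound 4 (3.52 log units; beyond the scatter) so this position can lose far more activity than the furan-3-yl result alone suggested. In place of 2-phenylethynyl it gives an at least 1.1-fold higher number from compound 2 to compound 4 (0.05 log units; that floor lies within the scatter) and that floor does not separate these two compounds.

From the compounds shown here alone, what a plain phenyl or a phenyl carrying an amine would give at this spot stays open, so the effects of the chlorine and of the six-membered ring cannot be told apart. Going by these compounds, how a longer chain on the triple-bonded carbon would compare with cyclopropyl also stays open.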